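Hydroxymethylbenzyl in Place of Bromobenzyl on a Nucleoside

This account rests on a few compounds, and the source may have more. Where it says the series, first, only, none or still open, it means among the compounds named here.

Compound 1 `OC[C@H]1O[C@@H](n2cnc3c(NCc4ccccc4Br)ncnc32)[C@H](O)[C@@H]1O`: 10000 nM
Compound 2 `Cc1ccc(CNc2ncnc3c2ncn3[C@@H]2O[C@H](CO)[C@@H](O)[C@H]2O)cc1`: > 166000 nM
Compound 3 `Cc1cccc(CNc2ncnc3c2ncn3[C@@H]2O[C@H](CO)[C@@H](O)[C@H]2O)c1O`: 18000 nM

Three compounds sharing one core were tested in a functional assay on K562 cells (Homo sapiens) for antiproliferative activity, with a stated time of 72 h; on this read-out higher numbers stand for weaker inhibition and lower numbers for stronger inhibition. Compound 1 gives 10000 nM and stands lowest of the two numbers reported, with compound 3, at 18000 nM, nearest. The value of compound 2 is a limit of the assay and not a number. Compound 2 sits at the limit of > 166000 nM in this assay, at which 1 of the 3 values shown sits.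

Compound 4 `Cc1ccc(O)c(CNc2ncnc3c2ncn3[C@@H]2O[C@H](CO)[C@@H](O)[C@H]2O)c1` has not yet been measured. It differs from compound 1 in one place: 2-hydroxy-5-methylphenyl in place of 2-bromophenyl on a saturated chain carbon bound to a nitrogen on an aromatic ring. Among the measured compounds shown here, two measured steps bear on this change. The step of an at least 16-fold higher number from compound 1 to compound 2 (1.22 log units; beyond the scatter) shows that a methylphenyl group alone drives the number out of range, whereas the step of a 1.8-fold higher number from compound 1 to compound 3 (0.26 log units; within the scatter) shows that a hydroxy-bearing, methyl-bearing phenyl keeps the number close to that of compound 1. Since compound 4 carries both hydroxyl and methyl groups, the outcome for compound 4 is expected to resemble compound 3 rather than compound 2, giving an expected step of a 2.0-fold higher number from compound 1 to compound 4 (0.30 log units; within the scatter), modestly upward. The estimate for compound 4 is 20000 nM, within 6000 nM to 80000 nM.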

Compound 4, half-maximal inhibitory concentration: 16500 nM
Compound 4: middle estimate off by 1.2-fold (0.08 log units), on the high side; measured number inside the range.
By their numbers in this assay, from the lowest: compounds 1, 4 and 3 (each within the scatter of the next). At a limit, above all of these: compound 2.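

In this assay, the change from 2-hydroxy-3-methylphenyl to 2-hydroxy-5-methylphenyl gives a 1.1-fold lower number from compound 3 to compound 4 (0.04 log units; within the scatter), so these two groups, which differ in where the methyl sits, are not told apart at this position. The 2-bromobenzyl to 2-hydroxy-5-methylbenzyl change also leaves the read-out within the scatter, with a 1.7-fold higher number from compound 1 to compound 4 (0.22 log units; within the scatter), whereas the comparison with the 4-methylphenyl group gives an at least 10-fold lower number from compound 2 to compound 4 (1.00 log units; beyond the scatter), so a second hydroxyl-bearing group now stands clear of compound 2, as does compound 1, which carries no hydroxyl. The value of compound 2 is a limit of the assay and not a number: the limit of > 166000 nM in this assay, at which 1 of the 4 values shown sits.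

The compounds shown leave open what the hydroxyl does without a methyl on the same ring. A 2-hydroxyphenyl, 2-methoxyphenyl or 2-aminophenyl group at this position would bear on that question.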